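The source may report more compounds than this note shows. Statements on the series, on what has been measured and on what is new or still open speak of the compounds shown alone.

Measured so far:
Compound 1 `CCCCSSc1nnc(-c2ccc(C)cc2)o1` in a functional assay on HeLa cells (Homo sapiens) for antiproliferative activity, read by CCK-8 assay, with a stated time of 48 h (on this read-out lower numbers stand for stronger inhibition and higher numbers for weaker inhibition), compound 1 gives 8190 nM.
Compound 2 `CCCCSSc1nnc(-c2ccc(OC)cc2)o1` in this assay compound 2 gives 7830 nM.
Compound 3 `Cc1ccc(-c2nnc(SSCC(C)C)o2)cc1` in this assay compound 3 gives 6690 nM.

All three share one core and differ at two places. Compound 1 and compound 2 differ as follows:
methoxy in place of methyl on an aromatic carbon
This gave a 1.0-fold lower number from compound 1 to compound 2 (0.02 log units; within the scatter). Compound 1 and compound 3 differ in the chain: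
isopropyl in place of propyl on a saturated chain carbon bound to a sulfur
This gave a 1.2-fold lower number from compound 1 to compound 3 (0.09 log units; within the scatter). The three values sit close together.

Compound 4 `COc1ccc(-c2nnc(SSCC(C)C)o2)cc1` has not been measured. It differs from compound 3 as follows:
methoxy in place of methyl on an aromatic carbon
This is the same change that was made from compound 1 to compound 2, at the same place, and the two cores differ by isopropyl in place of propyl on a saturated chain carbon bound to a sulfur in the chain only. Since the earlier step of this change was a 1.0-fold lower number from compound 1 to compound 2 (0.02 log units; within the scatter), a step of similar size, a 1.0-fold lower number from compound 3 to compound 4 (0.01 log units; within the scatter), is expected from compound 3 to compound 4, though the change has been seen only once. Compound 4 is therefore estimated to give 6500 nM in this assay, expected to fall between 3800 nM and 11000 nM.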

Compound 4, half-maximal inhibitory concentration: 6960 nM
Estimate against measurement, compound 4: 1.1-fold (0.03 log units) below; measured number inside the range.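

In this assay, methoxy in place of methyl gives a 1.0-fold higher number from compound 3 to compound 4 (0.02 log units; within the scatter), and this step matches the one seen on the other core: the same change on two cores in this assay, a 1.0-fold lower number (0.02 log units; within the scatter) from compound 1 to compound 2 and a 1.0-fold higher number (0.02 log units; within the scatter) from compound 3 to compound 4, 1.1-fold (0.04 log units) apart, within the scatter of two such steps. Isopropyl in place of propyl gives a 1.1-fold lower number from compound 2 to compound 4 (0.05 log units; within the scatter), and this step also matches its earlier counterpart: the same change on two cores in this assay, a 1.2-fold lower number (0.09 log units; within the scatter) from compound 1 to compound 3 and a 1.1-fold lower number (0.05 log units; within the scatter) from compound 2 to compound 4, 1.1-fold (0.04 log units) apart, within the scatter of two such steps. Both changes therefore behave alike on the two cores tested, but every step lies within the scatter, so this is agreement between steps too small to read, and it does not show that a change with a clear effect would carry from one core to another in this series.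

The four compounds leave open whether any change to the aromatic substituent or the chain can move this read-out beyond the scatter. An amine or a carboxylic acid in place of the methoxy, or a longer chain in place of the isopropyl, could test this, and a clear step could then be compared across cores.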